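Sulfonyl substituent variation on the shared alkyne core

The source may hold more compounds than are shown below. What is called first, only, known or untested is meant among the compounds shown, and "the series" means these compounds.

Measured so far:
compound 1, `Cc1ccc(S(=O)(=O)NC(C)C)cc1C#Cc1cc(Cl)ccc1OCC(=O)O`, 3.4 nM
compound 2, `CS(=O)(=O)c1cccc(C#Cc2cc(Cl)ccc2OCC(=O)O)c1`, 15 nM
compound 3, `Cn1ccnc1C#Cc1cc(Cl)ccc1OCC(=O)O`, 1470 nM

All three compounds keep the same acid-bearing core joined through an alkyne to a varied aromatic group, and all were tested in an assay on CHO cells for displacement of a labelled ligand from prostaglandin D2 receptor 2 (Homo sapiens), read by scintillation counting; on this read-out lower numbers stand for stronger inhibition and higher numbers for weaker inhibition. Compound 1 gives the lowest number of the three. Compound 2 stands nearest, with a number beyond the scatter above it, and compound 3 is furthest away, far weaker than either.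

Compound 4 is `Cc1ccc(S(=O)(=O)N2CCN(C)CC2)cc1C#Cc1cc(Cl)ccc1OCC(=O)O`, not yet measured. Against compound 1 the change is 4-methylpiperazin-1-yl in place of isopropylamino on a sulfonyl sulfur. The sulfonyl group and the whole of the shared core are kept; only the group on the sulfonyl sulfur is exchanged. Among the measured compounds shown here, no measured pair differs in just this way, so the step cannot be read off from the data. Compound 1 and compound 2 both sit well below compound 3, which suggests that a sulfonyl-bearing aromatic group is tolerated in more than one form, while compound 2 shows that what sits on the sulfur still matters.

The expected outcome is a modest loss, a 2.9-fold higher number from compound 1 to compound 4 (0.47 log units; beyond the scatter), a step expected to lie near the edge of the scatter. For compound 4 the estimated value is 10 nM, in a range from 2.5 nM to 40 nM.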

Compound 4, inhibition constant: 21 nM
Estimate against measurement, compound 4: 2.1-fold (0.32 log units) below; the measured number falls inside the stated range.
By their numbers in this assay, from the lowest: compound 1; then compounds 2 and 4 (each within the scatter of the next); then compound 3.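

In this assay, among the compounds shown here, 4-methylpiperazin-1-yl in place of isopropylamino on a sulfonyl sulfur gives a 6.2-fold higher number from compound 1 to compound 4 (0.79 log units; beyond the scatter), the first direct reading of this position, and the loss is modest. The exchange removes the hydrogen-bond donor of isopropylamino and brings in a larger group with a six-membered non-aromatic ring, yet compound 4 still gives 21 nM, so neither that donor nor a small open-chain group is essential for binding in the nanomolar range on this core. No measured property is available to account for the step, and this single exchange changes several features at once.

The compounds shown leave open whether the loss follows from the missing donor, from the ring, or from the second ring nitrogen: dimethylamino, cyclopropylamino, piperidin-1-yl and morpholin-4-yl on the same sulfur would help separate these. Also open, on these data alone, is how much the methyl on the piperazine contributes, a question that piperazin-1-yl or 4-acetylpiperazin-1-yl at this position would address.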